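This account rests on a few compounds, and the source may have more. Where it says the series, first, only, none or still open, it means among the compounds named here.

Compound 1 `COc1ccc(-c2ncnn2-c2cc(OC)c(OC)c(OC)c2)cc1`: 950 nM
Compound 2 `CCOc1ccc(-c2ncnn2-c2cc(OC)c(OC)c(OC)c2)cc1Cl`: 20 nM

Of the compounds shown here, two have been measured in a functional assay on K562 cells (Homo sapiens) for antiproliferative activity, read by MTT assay, with a stated time of 72 h; a higher number here means a weaker inhibitor, a lower number a stronger inhibitor. Compound 2 stands lowest of the two; compound 1 gives a number that is far higher, a gap well beyond the ordinary scatter of repeated measurements. Among the measured compounds shown here, the two measured compounds differ in more than one place, so no single step between them can be read off. Compound 3 `COc1cc(-n2ncnc2-c2cccc(Cl)c2)cc(OC)c1OC` is the next compound to be measured in this assay. It differs from compound 2 in one respect: hydrogen in place of ethoxy on an aromatic carbon. Taking away a group that sits para to a large group on that ring, while keeping the chloro group, leaves compound 3 with a smaller substituent set than compound 2. For the measured compounds named here, with no single step to lean on, the expectation is that compound 3 will be weaker than compound 2, by a step of a 25-fold higher number from compound 2 to compound 3 (1.40 log units; beyond the scatter). The estimated value for compound 3 is 500 nM, with a range from 100 nM to 3000 nM.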

Compound 3, half-maximal inhibitory concentration: > 10000 nM
Compound 3: a limit, no number (the forecaster's own chance of this, stated with the estimate: 5%); middle value at least 20-fold (1.30 log units) from the limit.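

In this assay, the ethoxy group of compound 2, which sits ortho to a chloro group and para to a large group, proves critical: replacing it with hydrogen gives an at least 500-fold higher number from compound 2 to compound 3 (2.69 log units; beyond the scatter). Placing 3-chlorophenyl where 4-methoxyphenyl stands gives an at least 10-fold higher number from compound 1 to compound 3 (1.02 log units; beyond the scatter), so a chloro group alone on this ring does not keep the activity on the shared core. Compound 3 gives a limit of the assay and not a number, so both steps are minimum sizes: the limit of > 10000 nM in this assay, at which 1 of the 3 values shown sits.

The compounds shown leave open whether the oxygen of the ethoxy group or its carbon chain matters more, and whether an amine or a longer chain such as propoxy at this place would keep the activity of compound 2. The share of the chloro group in that activity also remains unsettled.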